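Thioether arm replacement on the shared core: compound 3

A few compounds are considered here, and "the series" means these few. Any claim that something is new, unique, unknown or untested is made for them only; others in the source may bear on it.

Among the measured compounds shown here, the two measured members share one core and differ in the group carried on the sulfur. In a functional assay on MCF7 cells (Homo sapiens) for inhibition, read by MTT assay, with a stated time of 72 h (a higher number here means a weaker inhibitor, a lower number a stronger inhibitor), compound 1 `CCCCCc1c(C)nc2nc(SCc3ccc(Cl)cc3)nn2c1Nc1cc(-c2ccccc2)[nH]n1` gives 6390 nM. Compound 2 `Cc1cc(Nc2cc(-c3ccccc3)[nH]n2)n2nc(SCC(=O)c3ccccc3)nc2n1` gives 5240 nM in this assay, the lowest of the two numbers, although compound 1 sits within the scatter of it, so the pair shows no order. Compound 3 `Cc1cc(Nc2cc(-c3ccccc3)[nH]n2)n2nc(SCc3ccc(C(F)(F)F)cc3)nc2n1` differs from compound 2 only by 4-(trifluoromethyl)phenyl in place of benzoyl on a saturated chain carbon bound to a sulfur. For the measured compounds named here, no step between measured compounds is available for this kind of change, and the two numbers in hand lie close together, so the step is expected to be a 1.0-fold higher number from compound 2 to compound 3 (0.02 log units; within the scatter), not beyond the scatter in either direction. For compound 3 the expected value in this assay is 5500 nM, with a range from 2000 nM to 15000 nM, resting on compound 2 at 5240 nM.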

Compound 3, half-maximal inhibitory concentration: 4820 nM
The estimate for compound 3 lay 1.1-fold (0.06 log units) above the measured number; measured number inside the range.
By their numbers in this assay, from the lowest: compounds 3, 2 and 1 (each within the scatter of the next).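

In this assay, among the compounds shown here, the exchange of benzoyl for 4-(trifluoromethyl)phenyl on a saturated chain carbon bound to a sulfur gives a 1.1-fold lower number from compound 2 to compound 3 (0.04 log units; within the scatter), the first step that reads this position alone. The carbonyl and its hydrogen-bond acceptor leave and three fluorines enter, yet the two arms cannot be told apart in this read-out, so at this position the change gives no separation beyond the scatter. Nothing on hand gives a reason for this reading.

On these data alone, whether an amine or a carboxylic acid on the aromatic ring of this arm, or a longer chain on the sulfur, would move the number beyond the scatter stays open. Compound 1 differs from compound 3 in more than one place, so the contribution of its chain on the shared core cannot be read.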